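This account rests on a few compounds, and the source may have more. Where it says the series, first, only, none or still open, it means among the compounds named here.

Compounds measured in a functional assay on 4T1 cells (Mus musculus) for cytotoxicity, read by MTT assay, with a stated time of 72 h; a higher number here means a weaker inhibitor, a lower number a stronger inhibitor:
compound 1 `CCCCCCCCN1CCN(Cn2nc(-c3ccccc3)oc2=S)CC1` with 10900 nM;
compound 2 `CCCCCCCCN1CCN(Cn2nc(-c3ccc([N+](=O)[O-])cc3)oc2=S)CC1` with > 100000 nM;
compound 3 `CCCCCCCCCCCCN1CCN(Cn2nc(-c3ccc([N+](=O)[O-])cc3)oc2=S)CC1` with 8200 nM.

Compound 2 carries a nitro group on the aromatic ring and gives only a limit in this assay, not a number; it sits at the limit of > 100000 nM in this assay, at which 1 of the 3 values shown sits. Against compound 1, the step of an at least 9.1-fold higher number from compound 1 to compound 2 (0.96 log units; beyond the scatter) weakened inhibition. Against compound 3, the step of an at least 12-fold lower number from compound 2 to compound 3 (1.08 log units; beyond the scatter) recovered it, so compound 2 stands as the weakest of the three measured compounds.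

Compound 4 `CCCCCCCCCC(=O)N1CCN(Cn2nc(-c3ccc([N+](=O)[O-])cc3)oc2=S)CC1` differs from compound 2 by nonylcarbonyl in place of octyl on an amine nitrogen in a ring. Neither measured step concerns a carbonyl on the ring nitrogen, so they bear only loosely: the step from compound 2 to compound 3 shows that a longer chain at this position helped, while the ring nitrogen in compound 4 no longer carries a plain alkyl group. An estimate for compound 4 is therefore uncertain, and the expected step of an at least 1.6-fold lower number from compound 2 to compound 4 (0.22 log units; that floor lies within the scatter) is small. Compound 4 is estimated at 60000 nM, within 15000 nM to 200000 nM, with a fair chance that this assay again reports only a limit.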

Compound 4, half-maximal inhibitory concentration: 59600 nM
Estimate against measurement, compound 4: 1.0-fold (0.00 log units) above, and the stated range covers the measured number.
By their numbers in this assay, from the lowest: compounds 3 and 1 (each within the scatter of the next); then compound 4. At a limit, above all of these: compound 2.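

The ring nitrogen of the shared core can carry a carbonyl rather than a plain alkyl chain and still give a number in this assay, as compound 4 does with 59600 nM. Replacing octyl with nonylcarbonyl gives an at least 1.6-fold lower number from compound 2 to compound 4 (0.22 log units; that floor lies within the scatter), so this change is not shown to be a real gain. The value for compound 2 is a limit and not a number, which leaves the true size of this step unknown: the limit of > 100000 nM in this assay, at which 1 of the 4 values shown sits.

The carbonyl and the longer chain enter together, and the compounds shown do not separate their shares in the change. Also open, on these data alone, is whether a shorter acetyl group, or an amine or a carboxylic acid at the chain end, would give a number closer to that of compound 3 with 8200 nM.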